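A few compounds are considered here, and "the series" means these few. Any claim that something is new, unique, unknown or untested is made for them only; others in the source may bear on it.

Measured compounds:
- compound 1, `C/C(=C\c1cc(-c2cccnc2)co1)C(N)=O`: 8640 nM
- compound 2, `C/C(=C\c1cc(-c2ccc(F)cc2)cs1)C(N)=O`: > 50000 nM

Of the compounds shown here, two with the same amide-bearing side chain have been tested in a functional assay on HO8910 cells (Homo sapiens) for cytotoxicity, read by CCK-8 assay, with a stated time of 24 h; a higher number here means a weaker inhibitor, a lower number a stronger inhibitor. Compound 1 `C/C(=C\c1cc(-c2cccnc2)co1)C(N)=O` gives 8640 nM. For compound 2 `C/C(=C\c1cc(-c2ccc(F)cc2)cs1)C(N)=O` the assay reports no number but only a limit, > 50000 nM. Compound 2 thus stands at the weak end of the two results shown, sitting at the limit of > 50000 nM in this assay, at which 1 of the 2 values shown sits. Among the measured compounds shown here, since no step between measured compounds that differ in a single place is available, the two values can only be placed side by side: compound 1 has a number, compound 2 a limit.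

Compound 3 `C/C(=C\c1cc(-c2ccc(Cl)cc2)cs1)C(N)=O` is not yet measured. It differs from compound 2 by one change, (chloro in place of fluoro on an aromatic carbon). The step from compound 2 to compound 3 is expected to be small, none beyond the usual scatter, because the limit of > 50000 nM in this assay, at which 1 of the 2 values shown sits, gives the only anchor, and that anchor is a limit. Compound 3 is therefore estimated at 50000 nM, with a range from 20000 nM to 150000 nM; the step of a number no higher from compound 2 to compound 3 (the limit leaves the size open) that this estimate implies is expected to be essentially flat, and a further limit rather than a number is considered the more likely outcome.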

Compound 3, half-maximal inhibitory concentration: > 50000 nM
Compound 3: only a limit was reported; the forecaster's own chance of this, stated with the estimate: 65%; the middle value lies on the limit itself.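

Compound 2 and compound 3 both carry only a limit, so no step can be read between them for chloro in place of fluoro. The compounds shown leave open whether this exchange changes the cytotoxicity at all, and which structural difference goes with the numerical value of compound 1, which no single change links to either.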